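Hydroxy for Methoxy on a Cytotoxic Dimethylamino Analogue

A few compounds are considered here, and "the series" means these few. Any claim that something is new, unique, unknown or untested is made for them only; others in the source may bear on it.

Measured so far:
Compound 1, `COc1cc(C)cc(-c2c(-c3ccnc(-c4ccc(C(C)=O)cc4)c3)cnn2CC#N)c1`, gives 94% in a functional assay on RXF 393 cells (Homo sapiens) for cytotoxicity, read by sulforhodamine B assay, with a stated time of 48 h, tested at 100 nM; a lower number here means a stronger effect, a higher number a weaker effect of the compound at the concentration tested.
Compound 2, `Cc1cc(O)cc(-c2nn(CC#N)cc2-c2ccnc(-c3ccc(Oc4ccccc4)cc3)c2)c1`, gives 101% in this assay.
Compound 3, `COc1cc(C)cc(-c2nn(CC#N)cc2-c2ccnc(-c3ccc(N(C)C)cc3)c2)c1`, gives -25% in this assay.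

Compound 3 holds the lowest of the three numbers and thus the strongest effect of the set. Its nearest neighbour is compound 1, whose number lies higher by a margin beyond the usual scatter; compound 2 lies further still, also beyond the scatter. Among the measured compounds shown here, compounds 1 and 2 sit within the scatter of each other, and no measured pair differs in a single place.

Compound 4, `Cc1cc(O)cc(-c2nn(CC#N)cc2-c2ccnc(-c3ccc(N(C)C)cc3)c2)c1`, differs from compound 3 in one place: hydrogen in place of methyl on an oxygen on an aromatic ring. For the measured compounds named here, no measured pair shows this change alone. Compound 2 carries the hydroxy and compound 1 the methoxy, but they differ elsewhere too, so their numbers cannot isolate this step. The dimethylamino group shared by compound 3 and compound 4 is untouched. The account therefore expects only a small step in this assay toward a higher number, at most modestly beyond the scatter: a number 30 percentage points higher from compound 3 to compound 4 (beyond the scatter). Compound 4 is estimated at 5%, with a range from -40% to 70%.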

Compound 4, a percentage reported as activity, at one concentration (the size of the read-out at that concentration, not a potency): 120%
Compound 4: the middle estimate sits 115 percentage points below what was measured; the whole stated range lies below it.
By their numbers in this assay, from the lowest: compound 3; then compounds 1 and 2 (each within the scatter of the next); then compound 4.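

Removing the methyl from this oxygen gives a number 145 percentage points higher from compound 3 to compound 4 (beyond the scatter) in this assay and so, within this pair, the strong effect depends on the methoxy and does not survive with a hydroxy in its place. With the hydroxy kept, dimethylamino in place of phenoxy gives only a number 19 percentage points higher from compound 2 to compound 4 (beyond the scatter) and brings back none of the effect, so the dimethylamino group alone does not carry it. Nothing in the available data explains why this small change has so large a result.

On these data alone, it remains open whether an ethoxy group or a longer chain on the same oxygen, or an amine in place of the methoxy, would keep the effect. Also open, as far as these compounds go, is whether the methoxy has the same influence when phenoxy replaces dimethylamino.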